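A few compounds are considered here, and "the series" means these few. Any claim that something is new, unique, unknown or untested is made for them only; others in the source may bear on it.

Measured compounds:
compound 1 `CCc1nc2nc(-c3ccccc3)cc(C(F)(F)F)c2c(=O)n1Cc1cn(CCC(F)(F)C(F)(F)C(F)(F)C(F)(F)C(F)(F)C(F)(F)F)nn1` — > 200 ug/mL in a functional assay on U-937 cells (Homo sapiens) for cytotoxicity, read by MTT assay, with a stated time of 24 h; a lower number here means a stronger inhibitor, a higher number a weaker inhibitor
compound 2 `CCc1nc2nc(-c3ccccc3)cc(C(F)(F)F)c2c(=O)n1Cc1cn(CCC(F)(F)C(F)(F)C(F)(F)C(F)(F)C(F)(F)C(F)(F)C(F)(F)C(F)(F)F)nn1` — > 200 ug/mL
compound 3 `CCCCCCCCCCn1cc(Cn2c(CC)nc3nc(-c4ccccc4)cc(C(F)(F)F)c3c2=O)nn1` — 17.8 ug/mL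

Compound 1 gives only a limit in this assay; its value is not a number. Compound 2 likewise sits at a limit. Compound 3, with a decyl chain on its triazole, gives a measured number. The one-place step from compound 1 to compound 2, a step that the two limits leave unreadable from compound 1 to compound 2, cannot be sized, because both ends rest on (the limit of > 200 ug/mL in this assay, at which 2 of the 3 values shown sit).

Compound 4 `CCCCCCc1nc2nc(-c3ccccc3)cc(C(F)(F)F)c2c(=O)n1Cc1cn(CCC(F)(F)C(F)(F)C(F)(F)C(F)(F)C(F)(F)C(F)(F)C(F)(F)C(F)(F)F)nn1` differs from compound 2 only in butyl in place of hydrogen on a saturated chain carbon, two bonds along the chain from an aromatic carbon. Among the measured compounds shown here, no measured step alters the chain at that place, so nothing read so far bears directly on this change. With compound 2 at a limit, the step to compound 4 is expected to be unreadable or, at most, a modest move toward a measurable number; the expected step is a number no higher from compound 2 to compound 4 (the limit leaves the size open). Compound 4 is therefore estimated at 200 ug/mL, within 60 ug/mL to 600 ug/mL, with a good chance that this assay again returns only a limit.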

Compound 4, half-maximal inhibitory concentration: > 200 ug/mL
Compound 4: a limit, no number; the forecaster's own chance of this, stated with the estimate: 65%; the middle value lies on the limit itself.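

No new step can be read between compound 2 and compound 4, because each gives only a limit, not a number: the limit of > 200 ug/mL in this assay, at which 3 of the 4 values shown sit. The compounds shown leave open how large the change of butyl in place of hydrogen is, and in which direction it acts.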